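A few compounds are considered here, and "the series" means these few. Any claim that something is new, unique, unknown or untested is made for them only; others in the source may bear on it.

Compound 1 `Cc1ccccc1-n1nncc1CN1C(=O)C2(C(C#N)=C(N)Oc3c(N)cc4nc5ccccc5nc4c32)c2ccccc21` in an ADME assay on L02 cells (Homo sapiens) for antiproliferative activity, read by MTT assay, with a stated time of 48 h (a lower number here means a stronger inhibitor, a higher number a weaker inhibitor), gives > 50000 nM, which is a limit of the assay rather than a number.
Compound 2 `N#CC1=C(N)Oc2c(N)cc3nc4ccccc4nc3c2C12C(=O)N(Cc1cnnn1-c1cccc(Br)c1)c1ccccc12` in this assay gives > 50000 nM, again a limit and not a number.
Compound 3 `CCOc1ccc(-n2nncc2CN2C(=O)C3(C(C#N)=C(N)Oc4c(N)cc5nc6ccccc6nc5c43)c3ccccc32)cc1` in this assay gives > 50000 nM, once more a limit of the assay.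

Compound 3 therefore stands only at a limit in this assay, and the two further values shown are limits as well, so none of the three compounds can be placed against another. The three compounds differ only in the group on an aromatic nitrogen, and the steps between them are a step that the two limits leave unreadable from compound 1 to compound 2, a step that the two limits leave unreadable from compound 1 to compound 3 and a step that the two limits leave unreadable from compound 2 to compound 3. None of these steps can be given a size because of the limit of > 50000 nM in this assay, at which 3 of the 3 values shown sit.

Compound 4 `Cc1ccc(-n2nncc2CN2C(=O)C3(C(C#N)=C(N)Oc4c(N)cc5nc6ccccc6nc5c43)c3ccccc32)cc1Cl` has not yet been measured in this assay. Its difference from compound 3 is: 3-chloro-4-methylphenyl in place of 4-ethoxyphenyl on an aromatic nitrogen. All three measured steps bear on this change, since each swaps one aromatic group on that same nitrogen, but every one of them is unreadable, so no direction or size of step can be taken from them.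

The expectation is that compound 4 will also sit at the limit, so the step that the limit leaves unreadable from compound 3 to compound 4 is estimated to be none beyond the scatter. For compound 4 the estimated value in this assay is 80000 nM, expected to fall between 50000 nM and 300000 nM.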

Compound 4, half-maximal inhibitory concentration: > 50000 nM
Compound 4: no number, only a limit; the forecaster's own chance of this, stated with the estimate: 90%; the middle value is on the limit's open side.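

No step from compound 1, compound 2 or compound 3 to compound 4 can be read in this assay, because each value is a limit of the assay and not a number: the limit of > 50000 nM in this assay, at which 4 of the 4 values shown sit.

The compounds shown leave open how far these four lie from one another, and whether any group on that aromatic nitrogen gives a measurable value in this assay.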